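The compounds below may be only part of what the source reports. "The series", "measured", "known", "first", "only" and "open" are said of these compounds alone.

Measured so far, in a functional assay on CNE-2 cells (Homo sapiens) for cytotoxicity, read by MTT assay, with a stated time of 72 h; a higher number here means a weaker inhibitor, a lower number a stronger inhibitor:
- Compound 1 `COc1cc2ncnc(NNC(=S)NC(=O)c3ccc(Cl)cc3)c2cc1OC` gives 7530 nM.
- Compound 2 `COc1cc2ncnc(NNC(=S)NC(=O)c3ccccc3OC)c2cc1OC` gives 8410 nM.

Compound 2 has the highest of these two numbers, but its nearest neighbour, compound 1, sits only a small distance away: a 1.1-fold higher number from compound 1 to compound 2 (0.05 log units; within the scatter), a gap that lies within the ordinary scatter of repeated measurements. So the two compounds cannot be told apart on these values.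

The next compound, compound 3 `COc1cc2ncnc(NNC(=S)NC(=O)c3ccc(C)cc3)c2cc1OC`, differs from compound 2 at one spot on the shared core, (4-methylphenyl in place of 2-methoxyphenyl on a carbonyl carbon).

For the measured compounds named here, only one earlier step bears on this change, the exchange of one aromatic ring on the carbonyl carbon for another, from compound 1 to compound 2, and that step was too small to count. A third aromatic ring at the same place is therefore expected to stay in the same region, with no step beyond the scatter in either direction; the expected step is a 1.1-fold lower number from compound 2 to compound 3 (0.05 log units; within the scatter). For compound 3 the estimate in this assay is 7500 nM, with a likely range from 3000 nM to 20000 nM.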

Compound 3, half-maximal inhibitory concentration: 33300 nM
The estimate for compound 3 lay 4.4-fold (0.65 log units) below the measured number, outside the stated range (above it).
By their numbers in this assay, from the lowest: compounds 1 and 2 (each within the scatter of the next); then compound 3.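

In this assay, the aromatic ring on the carbonyl carbon can no longer be treated as freely exchangeable. 4-methylphenyl gives a weaker inhibitor than either earlier ring (a 4.0-fold higher number from compound 2 to compound 3 (0.60 log units; beyond the scatter)). The cleaner comparison is with the 4-chlorophenyl ring, where only methyl in place of chloro on an aromatic carbon changes (a 4.4-fold higher number from compound 1 to compound 3 (0.65 log units; beyond the scatter)), so a single small group on this ring is enough to move the number beyond the scatter, though only modestly. Nothing available here accounts for this shift.

The step from the 2-methoxyphenyl ring changes both the group and its numbered place on the ring, so these compounds cannot show which of the two matters; 4-methoxyphenyl or 2-methylphenyl would separate them. From the compounds shown here alone, it also remains open how the plain phenyl ring, or a ring carrying an amine, a carboxylic acid or a longer chain such as butyl, would compare at this spot, and whether chloro and 2-methoxy are both tolerated or merely happen to give close values.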